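A few compounds are considered here, and "the series" means these few. Any claim that something is new, unique, unknown or untested is made for them only; others in the source may bear on it.

Measured so far in a functional assay on HEK293 cells for negative allosteric modulation of metabotropic glutamate receptor 5 (Homo sapiens), read by calcium flux, with a stated time of 20 min; on this read-out higher numbers stand for weaker inhibition and lower numbers for stronger inhibition:
Compound 1, `O=C(c1ccccc1)N1CCn2nc(-c3ccncc3)cc2C1`, gives 1290 nM.
Compound 2, `O=C(c1ccccc1)N1CCn2nc(-c3cccnc3)cc2C1`, reaches only a limit of the assay, > 10000 nM.
Compound 3, `O=C(c1ccccc1)N1CCn2nc(-c3ccc(F)cn3)cc2C1`, gives 164 nM.

Compound 3 stands lowest of the two numbers; compound 1 is nearest, separated by a 7.9-fold lower number from compound 1 to compound 3 (0.90 log units; beyond the scatter). The other steps, an at least 7.7-fold higher number from compound 1 to compound 2 (0.88 log units; beyond the scatter) and an at least 60-fold lower number from compound 2 to compound 3 (1.78 log units; beyond the scatter), rest on the limit of > 10000 nM in this assay, at which 1 of the 3 values shown sits, and so give only bounds.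

Compound 4, `O=C(c1ccccc1)N1CCn2nc(-c3ccc(Cl)cn3)cc2C1`, differs from compound 3 by chloro in place of fluoro on an aromatic carbon. Going by the values given here, no measured step touches this position: every step so far exchanges the whole pyridyl ring, so none bears directly on a fluoro-to-chloro swap. The expected step of a 1.1-fold lower number from compound 3 to compound 4 (0.04 log units; within the scatter) is therefore estimated to stay within the usual scatter. For compound 4 the estimate in this assay is 150 nM, between 50 nM and 500 nM.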

Compound 4, half-maximal inhibitory concentration: 201 nM
The estimate for compound 4 lay 1.3-fold (0.13 log units) below the measured number; low and high end bracket the measured number.
By their numbers in this assay, from the lowest: compounds 3 and 4 (each within the scatter of the next); then compound 1. At a limit, above all of these: compound 2.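

Going by these compounds alone, on the carbon para to a large group, two atoms from the ring nitrogen, chloro in place of fluoro is the first exchange of a single atom, and it gives a 1.2-fold higher number from compound 3 to compound 4 (0.09 log units; within the scatter), so the two halogens cannot be told apart in this assay. The 5-chloropyridin-2-yl ring also stands clear of pyridin-4-yl, with a 6.4-fold lower number from compound 1 to compound 4 (0.81 log units; beyond the scatter). Against pyridin-3-yl, an at least 49-fold lower number from compound 2 to compound 4 (1.69 log units; beyond the scatter) gives only a bound: the limit of > 10000 nM in this assay, at which 1 of the 4 values shown sits.

On these data alone, how a nitrile, a methyl or a methoxy would read at this position stays open. Also open, as far as these compounds go, is how much of the gap to compound 1 belongs to the halogen and how much to the place of the ring nitrogen, which an unsubstituted pyridin-2-yl would separate.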